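This account rests on a few compounds, and the source may have more. Where it says the series, first, only, none or still open, it means among the compounds named here.

Series notes. Three compounds on a shared core have numbers in a functional assay for inhibition of sodium/hydrogen exchanger (Oryctolagus cuniculus); on this read-out higher numbers stand for weaker inhibition and lower numbers for stronger inhibition. Compound 1 `Cc1cc(Br)c(C(=O)N=C(N)N)cc1S(C)(=O)=O` gives 70 nM. Compound 2 `Cc1cc(-c2ccc(Cl)cc2)c(S(C)(=O)=O)cc1C(=O)N=C(N)N` gives 45 nM. Compound 3 `CSc1cc(C)c(C(=O)N=C(N)N)cc1S(C)(=O)=O` gives 6 nM, the lowest of the three; the nearest is compound 2 and the furthest compound 1, and both gaps are beyond the scatter. Within the data shown here, the only measured step that changes this position runs a 7.5-fold lower number from compound 2 to compound 3 (0.88 log units; beyond the scatter), so at that carbon methylsulfanyl gives the lower number and 4-chlorophenyl the higher. Compound 4 `Cc1cc(Oc2ccccc2Cl)c(S(C)(=O)=O)cc1C(=O)N=C(N)N` is not yet measured. It differs from compound 3 by 2-chlorophenoxy in place of methylsulfanyl on an aromatic carbon. The entering group is, like 4-chlorophenyl in compound 2, a chlorine-bearing six-membered aromatic ring of carbon only, here joined through an oxygen. Going by these compounds, the step from compound 2 to compound 3 therefore bears on it and points the other way: a higher number for compound 4 than for compound 3, of roughly the size seen there, though the oxygen link is untested in this set. Compound 4 is expected to give 30 nM, between 10 nM and 100 nM, an expected step of a 5.0-fold higher number from compound 3 to compound 4 (0.70 log units; beyond the scatter).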

Compound 4, half-maximal inhibitory concentration: 14 nM
For compound 4 the middle estimate is 2.1-fold (0.33 log units) above the measured one, and the stated range covers the measured number.
By their numbers in this assay, from the lowest: compound 3; then compound 4; then compounds 2 and 1 (each within the scatter of the next).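

At this carbon, ortho to a methylsulfonyl group, methylsulfanyl still gives the lowest number in this assay, yet the larger 2-chlorophenoxy group stays fairly close to it (a 2.3-fold higher number from compound 3 to compound 4 (0.37 log units; beyond the scatter)). Against the other chlorine-bearing aromatic group, 2-chlorophenoxy gives the lower number (a 3.2-fold lower number from compound 2 to compound 4 (0.51 log units; beyond the scatter)), so such a ring at this carbon does not always bring the number up to the level of compound 2. Nothing in hand explains either step.

The change from 4-chlorophenyl to 2-chlorophenoxy alters both the oxygen link and the chlorine placement, so the compounds shown do not separate the two. Also open, going by these compounds, is how this carbon responds to unsubstituted phenoxy, 4-chlorophenoxy, a longer sulfur chain such as ethylsulfanyl, or an amine such as dimethylamino.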